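Ethyl to methyl on a short chain

The source may report more compounds than this note shows. Statements on the series, on what has been measured and on what is new or still open speak of the compounds shown alone.

Measured in an ADME assay on FSCLL cells (Homo sapiens) for cytotoxicity, read by MTT assay, with a stated time of 24 h; a higher number here means that more compound is tolerated, a lower number that less compound is tolerated:
Compound 1 `CCC[C@H](N)C(=O)N[C@@H](CC(C)C)B(O)O` gives 1100 nM
Compound 2 `CC[C@H](N)C(=O)N[C@@H](CC(C)C)B(O)O` gives 1500 nM

These two numbers lie within the usual scatter of each other, so compound 2 with its 1500 nM cannot be told apart from compound 1 in this assay. The next compound to be tested is compound 3 `CC(C)C[C@H](NC(=O)[C@H](C)N)B(O)O`. Its difference from compound 2 is hydrogen in place of methyl on a saturated chain carbon, two bonds along the chain from an amine nitrogen and a carbonyl carbon, which shortens an ethyl to a methyl.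

Among the measured compounds shown here, only one measured step bears on this: a 1.4-fold higher number from compound 1 to compound 2 (0.13 log units; within the scatter). That step is the same kind of swap, hydrogen in place of methyl, but it sits three bonds along the chain rather than two. It is small, and a single step at another place on the chain is thin evidence. No change beyond the scatter is therefore expected in this assay, though a slight drift in the same direction would not surprise. The expected size is a 1.2-fold higher number from compound 2 to compound 3 (0.08 log units; within the scatter). For compound 3 the estimated value is 1800 nM, with an expected range from 800 nM to 4000 nM.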

Compound 3, half-maximal cytotoxic concentration: 3200 nM
Compound 3: middle estimate off by 1.8-fold (0.25 log units), on the low side, within the range that was stated.
By their numbers in this assay, from the lowest: compounds 1 and 2 (each within the scatter of the next); then compound 3.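

Shortening ethyl to methyl on this saturated chain carbon, two bonds along the chain from an amine nitrogen and a carbonyl carbon, gives the first step in this assay that lies beyond the scatter (a 2.1-fold higher number from compound 2 to compound 3 (0.33 log units; beyond the scatter)), so less toxicity to these cells goes with this one change. Hydrogen in place of ethyl at the same carbon gives a step of the same modest class (a 2.9-fold higher number from compound 1 to compound 3 (0.46 log units; beyond the scatter)), which sets compound 3 apart from both of the other compounds, while those two remain within the scatter of each other. No supporting data bear on why this change moves the number, so the result stands as an observation only.

With only ethyl, methyl and a propyl chain shown at this carbon, it remains open whether a bare hydrogen would move the number further or whether a longer chain, a hydroxymethyl or a carboxylic acid would reverse it. These compounds also leave open whether the same step would appear in other cell types or at other exposure times.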